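Second chloro on the chlorophenyl arm of compound 3

The source may report more compounds than this note shows. Statements on the series, on what has been measured and on what is new or still open speak of the compounds shown alone.

Compound 3 `COc1ccc(/C=C2\CCC/C(=C\c3ccccc3Cl)C2=O)cc1OC` gives 7100 nM in a functional assay on SW-620 cells (Homo sapiens) for cytotoxicity, read by MTT assay, with a stated time of 72 h (a higher number here means a weaker inhibitor, a lower number a stronger inhibitor), the second highest of the three numbers and within the scatter of both others: compound 2 `COc1cccc(/C=C2\CCC/C(=C\c3cccc(OC)c3OC)C2=O)c1` gives 7000 nM and compound 1 `COc1cccc(/C=C2\CCC/C(=C\c3cccc(Br)c3)C2=O)c1OC` gives 8800 nM. Compound 4 `COc1ccc(/C=C2\CCC/C(=C\c3ccc(Cl)cc3Cl)C2=O)cc1OC` differs from compound 3 by chloro in place of hydrogen on an aromatic carbon, so 2-chlorophenyl becomes 2,4-dichlorophenyl. Among the compounds with values here, the only step measured, a 1.3-fold lower number from compound 1 to compound 2 (0.10 log units; within the scatter), concerns a different change and stayed within the scatter; no measured step adds a halogen to an already substituted arm. Nothing here supports a shift beyond the scatter in this assay in either direction. Compound 4 is therefore expected to give 7000 nM (range 3000 nM to 16000 nM), with a 1.0-fold lower number from compound 3 to compound 4 (0.01 log units; within the scatter) expected to stay within the scatter.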

Compound 4, half-maximal inhibitory concentration: 10300 nM
For compound 4 the middle estimate is 1.5-fold (0.17 log units) below the measured one; low and high end bracket the measured number.
By their numbers in this assay, from the lowest: compounds 2, 3, 1 and 4 (each within the scatter of the next).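

In this assay, chloro in place of hydrogen on an aromatic carbon, meta to a chloro group and para to a large group, gives a 1.5-fold higher number from compound 3 to compound 4 (0.16 log units; within the scatter). This is the only step shown that adds a halogen to an already substituted arm, and 2,4-dichlorophenyl stays within the scatter of 2-chlorophenyl. No measured evidence bears on this result. As far as these compounds go, whether an amine or a carboxylic acid at this position would move the number beyond the scatter remains open. So does whether chloro added to the dimethoxyphenyl arm would do so.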